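Trimming the Branch: Isopropyl to Methyl on a Kinase Inhibitor

The source may hold more compounds than are shown below. What is called first, only, known or untested is meant among the compounds shown, and "the series" means these compounds.

Three compounds have been measured in an assay on isolated protein for inhibition of sphingosine kinase 1 (Homo sapiens); on this read-out higher numbers stand for weaker inhibition and lower numbers for stronger inhibition:
- compound 1, `CCCCCCCc1cc(-c2ccc(CNC(=O)[C@H]3NCC[C@@H]3O)cc2)n[nH]1`, gives 1100 nM
- compound 2, `O=C(NCc1ccc(-c2noc(CCC3CC3)n2)cc1)[C@H]1NCC[C@@H]1O`, gives 5000 nM
- compound 3, `CCCCCCCc1nc(-c2ccc([C@@H](NC(=O)[C@H]3NCC[C@@H]3O)C(C)C)cc2)no1`, gives 110 nM

Compound 3 has the lowest number of the three, so it is the strongest inhibitor here; compound 1 sits well above it and compound 2 further still, both gaps lying beyond the usual scatter. Compound 4, `CCCCCCCc1nc(-c2ccc([C@H](C)NC(=O)[C@H]3NCC[C@@H]3O)cc2)no1`, has not yet been measured. It differs from compound 3 in a single place: methyl in place of isopropyl on a saturated chain carbon bound to an amide-type nitrogen and an aromatic carbon. Among the compounds with values here, no pair of measured compounds differs only in this way, so nothing in the data shows directly how shrinking this branch plays out. The closest hint is compound 1, whose carbon bound to the amide nitrogen carries no branch at all and which gives 1100 nM, clearly weaker than compound 3, though its core also differs. On that basis compound 4 is expected to lose some potency, with a step of about a 2.7-fold higher number from compound 3 to compound 4 (0.44 log units; beyond the scatter) in this assay. Compound 4 is therefore estimated at 300 nM, within a range from 100 nM to 1000 nM.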

Compound 4, half-maximal inhibitory concentration in the sphingosine kinase 1 assay: 48 nM
Estimate against measurement, compound 4: 6.3-fold (0.80 log units) above; the measured number lies below the stated range.
By their numbers in the sphingosine kinase 1 assay, from the lowest: compound 4; then compound 3; then compound 1; then compound 2.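

In the sphingosine kinase 1 assay, replacing isopropyl with methyl on this saturated chain carbon gives a 2.3-fold lower number from compound 3 to compound 4 (0.36 log units; beyond the scatter), so the larger branch is not needed for inhibition in this series. Within the data shown here, the earlier compounds could not show this, as no two of them differed in one place only, and the single pair now available points the opposite way from a simple rule that more branch means stronger inhibition. In a physicochemical assay for solubility, at pH 7.4 (a lower number here means a less soluble compound, a higher number a more soluble compound), compound 3 gives 3 ug/mL and compound 4 gives 27 ug/mL, so the same change also brings a clear gain, and the smaller group improves both read-outs together in this pair: the measured solubility of compound 3, 3 ug/mL, and of compound 4, 27 ug/mL, a 9.0-fold higher number (0.95 log units; beyond the scatter)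

One pair cannot show how inhibition and solubility follow the size of the group at this carbon. An ethyl or a hydroxymethyl group on the same carbon, with the rest of compound 4 unchanged, would test whether methyl is the best choice here.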